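Moving the fluorine on the arylamine: working notes

The source may hold more compounds than are shown below. What is called first, only, known or untested is meant among the compounds shown, and "the series" means these compounds.

Measured compounds, with their numbers in a functional assay on MDA-MB-231 cells (Homo sapiens) for cytotoxicity, read by MTT assay, with a stated time of 48 h; on this read-out lower numbers stand for stronger inhibition and higher numbers for weaker inhibition:

Compound 1, `Fc1cccc(-c2nc(Nc3ccccc3)c3cc(F)ccc3n2)c1`, gives 47800 nM.
Compound 2, `COc1ccc(Nc2nc(-c3cccc(F)c3)nc3ccc(F)cc23)cc1`, gives 47300 nM.
Compound 3, `Fc1ccc(Nc2nc(-c3cccc(F)c3)nc3ccc(F)cc23)cc1`, reaches only the assay limit of > 50000 nM, which is a limit and not a number.

Compound 3 therefore sits at the floor of the series: the limit of > 50000 nM in this assay, at which 1 of the 3 values shown sits. Its neighbours are no more informative. The step of a 1.0-fold lower number from compound 1 to compound 2 (0.00 log units; within the scatter) is within the scatter, as is an at least 1.0-fold higher number from compound 1 to compound 3 (0.01 log units; that floor lies within the scatter) and an at least 1.0-fold higher number from compound 2 to compound 3 (0.02 log units; that floor lies within the scatter). Across the three measured compounds the substituent on the arylamine ring, whether hydrogen, methoxy or fluoro, leaves the read-out unchanged within the scatter.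

Compound 4, `Fc1cccc(-c2nc(Nc3ccccc3F)c3cc(F)ccc3n2)c1`, is not yet measured. It differs from compound 3 as follows: 2-fluorophenyl in place of 4-fluorophenyl on a nitrogen on an aromatic ring. Going by the values given here, no measured step bears directly on the 2-fluorophenyl; the three measured steps all concern substituents on the same arylamine nitrogen and all are within the scatter, so a shift of the fluorine within that ring is expected to behave the same way. Compound 4 is therefore expected to show no step beyond the scatter, a number no higher from compound 3 to compound 4 (the limit leaves the size open), with a fair chance that only a limit is reported again.

The estimate for compound 4 in this assay is 50000 nM, ranging from 25000 nM to 100000 nM.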

Compound 4, half-maximal inhibitory concentration: > 50000 nM
Compound 4 was reported as a limit (the forecaster's own chance of this, stated with the estimate: 60%); the middle value sits exactly at the limit.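

Moving the fluorine from 4-fluorophenyl to 2-fluorophenyl on the nitrogen gives a second limit in this assay, so the step between compound 3 and compound 4 cannot be read, and the floor of the series now reads: the limit of > 50000 nM in this assay, at which 2 of the 4 values shown sit.

The readable comparisons are an at least 1.0-fold higher number from compound 2 to compound 4 (0.02 log units; that floor lies within the scatter) and an at least 1.0-fold higher number from compound 1 to compound 4 (0.01 log units; that floor lies within the scatter). With 2-fluorophenyl added, this position has now carried four groups on the nitrogen, and none of them gives a read-out separated from the others by more than the scatter, though the two limits leave the true values of compound 3 and compound 4 open.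

The compounds shown leave open whether any group on this ring can bring the read-out clear of the limit, for instance an amine, a carboxylic acid or a longer alkoxy chain in place of the methoxy of compound 2. They also leave open whether a change on the shared core, rather than on the arylamine ring, would move the read-out at all.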